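Compound 2 to compound 3: phenyl to 4-fluorophenyl

A few compounds are considered here, and "the series" means these few. Any claim that something is new, unique, unknown or untested is made for them only; others in the source may bear on it.

Measured in a physicochemical assay for lipophilicity, at pH 7.4; a higher number here means a more lipophilic compound, a lower number a more polar compound
- compound 1 `CNC(=O)C1CCN(c2cncnc2-c2ccccc2)CC1` gives 1.4
- compound 2 `CN(C)C(=O)C1CCN(c2cncnc2-c2ccccc2)CC1` gives 1.7

On these two numbers, compound 2 stands within the scatter of compound 1, so neither stands apart from the other. Compound 3 `CN(C)C(=O)C1CCN(c2cncnc2-c2ccc(F)cc2)CC1` differs from compound 2 in one place (fluoro in place of hydrogen on an aromatic carbon): fluoro in place of hydrogen on an aromatic carbon, para to a large group, which turns phenyl into 4-fluorophenyl. Among the compounds with values here, only one measured step exists (a number 0.30 log units higher from compound 1 to compound 2 (within the scatter)), and it is methyl in place of hydrogen on an amide-type nitrogen. Within the data shown here, that is another change at another place, so it bears only loosely on this one, and no measured step covers fluoro. The expectation therefore starts from compound 2 at 1.7 and allows only a small change in this assay. A slight rise is expected, with the estimated step being a number 0.20 log units higher from compound 2 to compound 3 (within the scatter) and not clearly beyond the scatter. Compound 3 is thus estimated at 1.9 (expected range 1.6 to 2.2).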

Compound 3, distribution coefficient: 1.9
Compound 3: middle estimate and measured number agree at the digits printed, within the range that was stated.
By their numbers in this assay, from the lowest: compounds 1, 2 and 3 (each within the scatter of the next, the first and the last beyond it).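

In this assay, fluoro in place of hydrogen on an aromatic carbon, para to a large group, gives a number 0.20 log units higher from compound 2 to compound 3 (within the scatter) and so does not set compound 3 apart from compound 2. Within the data shown here, the only earlier step, a number 0.30 log units higher from compound 1 to compound 2 (within the scatter) at the amide nitrogen, said nothing about the phenyl group, and this is the first reading at that aromatic carbon, where a single fluorine atom leaves the number inside the scatter. No measurement at hand accounts for the size of this step. The compounds shown leave open whether trifluoromethyl, methoxy or an amine in the same place would give a step beyond the scatter. They also leave open whether the same fluoro change would give a similar step with the amide hydrogen of compound 1 still in place.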